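A few compounds are considered here, and "the series" means these few. Any claim that something is new, unique, unknown or untested is made for them only; others in the source may bear on it.

Compound 1, `CCCCCCC(CCCCCC(=O)Nc1ccccc1)C(=O)NO`: 2000 nM
Compound 2, `CCCCCC[C@H](CCCCCC(=O)Nc1ccccc1)C(=O)NO`: 710 nM

In an assay for inhibition of histone deacetylase 8 (Homo sapiens), read by ELISA, with stated times of 15 min and 45 min (a higher number here means a weaker inhibitor, a lower number a stronger inhibitor), compound 1 gives 2000 nM, and compound 2 gives 710 nM. Among the measured compounds shown here, compound 2 holds the lowest of the two numbers measured so far; its only neighbour is compound 1, with a 2.8-fold lower number from compound 1 to compound 2 (0.45 log units; beyond the scatter). That step may be read in the light of the fact that one of compounds 1 and 2 is drawn with a defined configuration and the other without, at the place where they differ: compound 1 is drawn without a configuration at the stereocentre at a saturated chain carbon, so it may contain both mirror forms, while compound 2 is the single form drawn R.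

Compound 3, `CCCCCC[C@@H](CCCCCC(=O)Nc1ccccc1)C(=O)NO`, has not yet been measured. It differs from compound 2 only in that (the two compounds have the same atoms and bonds and differ only in configuration as drawn: 1 of 1 stereo elements differ; a stereocentre at a saturated chain carbon is drawn R in compound 2 and S in compound 3). Compound 3 is therefore the mirror image of compound 2. For the measured compounds named here, the only measured step that bears on this change is a 2.8-fold lower number from compound 1 to compound 2 (0.45 log units; beyond the scatter), which went towards a lower number when the configuration was fixed as R. If the form present in compound 2 accounts for that lower number, the other mirror form is expected to give a higher number. The expected step is an 8.5-fold higher number from compound 2 to compound 3 (0.93 log units; beyond the scatter), towards a weaker inhibitor. For compound 3 in this assay the estimate is 6000 nM, with a range from 2000 nM to 20000 nM.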

Compound 3, half-maximal inhibitory concentration: 3100 nM
Compound 3: middle estimate off by 1.9-fold (0.29 log units), on the high side; the range from low to high includes it.
By their numbers in this assay, from the lowest: compound 2; then compounds 1 and 3 (each within the scatter of the next).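

In this assay, the two mirror forms at this saturated chain carbon clearly part ways, with a 4.4-fold higher number from compound 2 to compound 3 (0.64 log units; beyond the scatter), and the R form, compound 2, is the stronger inhibitor of the pair; this gap can be tied to the configuration at that one carbon: the fact that compounds 2 and 3 differ only in the configuration as drawn. Before this, only a 2.8-fold lower number from compound 1 to compound 2 (0.45 log units; beyond the scatter) pointed towards the R form, and since compound 1 may contain both mirror forms, that step could not show how far apart the two forms lie: the fact that one of compounds 1 and 2 is drawn with a defined configuration and the other without, at the place where they differ. The S form cannot be told apart from the compound drawn without a configuration, with a 1.6-fold higher number from compound 1 to compound 3 (0.19 log units; within the scatter), so fixing this stereocentre as S gives no measurable change from compound 1, whereas fixing it as R does: the fact that one of compounds 1 and 3 is drawn with a defined configuration and the other without, at the place where they differ.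

Going by these compounds, whether the R form keeps its edge with a longer chain at the stereocentre, or with an amine added to the shared core, stays open. These three compounds also cannot show whether the same gap between mirror forms would appear against any other histone deacetylase.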